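This account rests on a few compounds, and the source may have more. Where it says the series, first, only, none or still open, it means among the compounds named here.

Measured compounds:
compound 1 `COc1ccc(CCC[C@@H]2C[C@@H]([C@@H](O)c3ccc(OC)c(OC)c3)CO[C@H]2c2ccc(OC)c(OC)c2)cc1OC`: 35700 nM
compound 2 `Oc1cccc(/C=C/C[C@H]2C[C@@H]([C@@H](O)c3ccccc3)CO[C@@H]2c2ccccc2)c1`: 18600 nM

Both numbers come from a functional assay on HeLa cells (Homo sapiens) for cytotoxicity, read by WST assay, with a stated time of 48 h; on this read-out lower numbers stand for stronger inhibition and higher numbers for weaker inhibition. In this assay compound 1 gives 35700 nM, and compound 2 gives 18600 nM. Compound 2 thus holds the lower of the two numbers, but the gap to compound 1 lies within the usual scatter of repeated measurements, so the two compounds cannot be told apart on this read-out, and neither can be called the more active.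

Compound 3 `O=[N+]([O-])c1ccc(/C=C/C[C@H]2C[C@@H]([C@@H](O)c3ccccc3)CO[C@@H]2c2ccccc2)cc1` is the next compound to be tested in this assay. It keeps the shared core of compound 2 and differs from it in one place: 4-nitrophenyl in place of 3-hydroxyphenyl on a double-bonded chain carbon bound to a double-bonded chain carbon. For the measured compounds named here, no pair of measured compounds shows this change, so there is no measured step that tells how large a shift it brings, or in which direction.

With nothing to rest on beyond the two measured values, the step from compound 2 to compound 3 is expected to be a 1.1-fold higher number from compound 2 to compound 3 (0.03 log units; within the scatter), that is, none beyond the scatter. Compound 3 is therefore estimated at 20000 nM, with a range from 7000 nM to 60000 nM in this assay.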

Compound 3, half-maximal inhibitory concentration: 12400 nM
Beside the measured number, compound 3's estimate is 1.6-fold (0.21 log units) above it; low and high end bracket the measured number.
By their numbers in this assay, from the lowest: compounds 3, 2 and 1 (each within the scatter of the next, the first and the last beyond it).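

In this assay, for the compounds shown here, the first measured swap at this place, on a double-bonded chain carbon bound to a double-bonded chain carbon, gives a 1.5-fold lower number from compound 2 to compound 3 (0.18 log units; within the scatter). Compound 2 and compound 3 therefore cannot be told apart on this read-out, even though 3-hydroxyphenyl carries a hydrogen-bond donor and 4-nitrophenyl has none, so in this one pair that donor is not needed for a number in this range. The swap replaces the hydroxyl with a nitro group and also moves the substituent on the ring, so this pair cannot show what either part of the swap does alone, and no measurement on hand explains the result.

On these data alone, it remains open whether any group at this place can move the number beyond the scatter, for example an amine or a carboxylic acid on the phenyl ring, or a plain unsubstituted phenyl. As far as these compounds go, it is also open whether a longer chain carrying the ring would matter, since the chain is the same in compound 2 and compound 3.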